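Swapping the heteroaryl on a diphenylmethyl sulfoxide

The compounds below may be only part of what the source reports. "The series", "measured", "known", "first", "only" and "open" are said of these compounds alone.

Measured compounds:
- compound 1, `Cc1noc(C[S+]([O-])C(c2ccccc2)c2ccccc2)n1`: 56700 nM
- compound 2, `[O-][S+](Cc1ccncc1)C(c1ccccc1)c1ccccc1`: 63500 nM
- compound 3, `Cc1nc(O)cc(C[S+]([O-])C(c2ccccc2)c2ccccc2)n1`: 3100 nM

All three share a diphenylmethyl sulfoxide core and differ only in the aromatic group on the saturated chain carbon bound to the sulfur. In an assay on HEK293 cells for inhibition of sodium-dependent dopamine transporter (Homo sapiens), read by scintillation counting, with stated times of 5 min and 1 min (on this read-out lower numbers stand for stronger inhibition and higher numbers for weaker inhibition), compound 3 stands lowest of the three, with compound 1 nearest, the step being an 18-fold lower number from compound 1 to compound 3 (1.26 log units; beyond the scatter), and compound 2 furthest, the step being a 20-fold lower number from compound 2 to compound 3 (1.31 log units; beyond the scatter). Compounds 1 and 2 sit close together, as the step of a 1.1-fold higher number from compound 1 to compound 2 (0.05 log units; within the scatter) shows.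

Compound 4, `[O-][S+](Cc1ccsc1)C(c1ccccc1)c1ccccc1`, has not yet been measured. It differs from compound 3 by thiophen-3-yl in place of 6-hydroxy-2-methylpyrimidin-4-yl on a saturated chain carbon bound to a sulfur. The two steps that bear on it are those leading into compound 3: both times a small aromatic group without a hydroxyl, whether the oxadiazolyl of compound 1 or the pyridyl of compound 2, gave a much higher number than compound 3. Thiophen-3-yl resembles those two groups more than the hydroxy-methylpyrimidinyl, so a large step upward in this assay is expected for compound 4, of about a 15-fold higher number from compound 3 to compound 4 (1.16 log units; beyond the scatter). Compound 4 is therefore estimated at 45000 nM, within a range from 12000 nM to 150000 nM.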

Compound 4, half-maximal inhibitory concentration: 3000 nM
Compound 4: middle estimate off by 15-fold (1.18 log units), on the high side; measured number outside the range, below it.
By their numbers in this assay, from the lowest: compounds 4 and 3 (each within the scatter of the next); then compounds 1 and 2 (each within the scatter of the next).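

In this assay, thiophen-3-yl and 6-hydroxy-2-methylpyrimidin-4-yl on a saturated chain carbon bound to a sulfur give numbers that cannot be told apart, with a 1.0-fold lower number from compound 3 to compound 4 (0.01 log units; within the scatter), so a low number at this position does not require a hydroxyl or a hydrogen-bond donor on the aromatic group. The lack of a hydroxyl does not by itself mark the weaker compounds either, since thiophen-3-yl has none and still stands well clear of both pyridin-4-yl, with a 21-fold lower number from compound 2 to compound 4 (1.33 log units; beyond the scatter), and 3-methyl-1,2,4-oxadiazol-5-yl, with a 19-fold lower number from compound 1 to compound 4 (1.28 log units; beyond the scatter). The data offer no measurement that accounts for why these very different groups fall into two such separate pairs.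

The compounds shown leave open whether a plain phenyl, a furan-3-yl or a thiophen-2-yl on this carbon would read with compound 3 and compound 4 or with compound 1 and compound 2. They also leave open whether a primary amine or a carboxylic acid on the thiophen-3-yl ring would lower the number further or raise it.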